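This account rests on a few compounds, and the source may have more. Where it says the series, first, only, none or still open, it means among the compounds named here.

Compound 2 `CCCCCCCCCCCOc1ccc(OC)cc1C(SCCC(=O)O)SCCC(=O)O` gives, in an assay on membranes from lung (Cavia porcellus) for binding affinity to cysteinyl leukotriene receptor (Homo sapiens) (a higher number here means a weaker inhibitor, a lower number a stronger inhibitor), a value of 579 nM. Among the compounds with values here, it stands highest of the two numbers measured so far; the nearest is compound 1 `CCCCCCCCCCCOc1ccc(O)cc1C(SCCC(=O)O)SCCC(=O)O`, which in this assay gives 156 nM, and the measured step is a 3.7-fold higher number from compound 1 to compound 2 (0.57 log units; beyond the scatter). Compound 3 `CCCCCCCCCCCOc1ccc([N+](=O)[O-])cc1C(SCCC(=O)O)SCCC(=O)O` differs from compound 2 by nitro in place of methoxy on an aromatic carbon. Within the data shown here, the only measured step, a 3.7-fold higher number from compound 1 to compound 2 (0.57 log units; beyond the scatter), shows that exchanging the group at this aromatic carbon can move the number beyond the scatter, but no measured step covers a nitro group there, so the direction of the change cannot be read from the data. The step from compound 2 to compound 3 is therefore expected to be a 1.4-fold lower number from compound 2 to compound 3 (0.16 log units; within the scatter), a shift inside or just beyond the scatter. For compound 3 the value in this assay is estimated at 400 nM, with a range from 130 nM to 1300 nM.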

Compound 3, inhibition constant: 303 nM
Estimate against measurement, compound 3: 1.3-fold (0.12 log units) above; the measured number falls inside the stated range.
By their numbers in this assay, from the lowest: compounds 1, 3 and 2 (each within the scatter of the next, the first and the last beyond it).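

In this assay, the nitro group at this aromatic carbon gives a 1.9-fold lower number from compound 2 to compound 3 (0.28 log units; within the scatter), and set against the hydroxy group it gives a 1.9-fold higher number from compound 1 to compound 3 (0.29 log units; within the scatter). Within the data shown here, the nitro compound therefore cannot be told apart from either earlier compound, although those two lie beyond the scatter of each other, so the three groups do not form a clear order and hydroxy against methoxy remains the only exchange here with a readable effect. No measurement is available that bears on the reason for this result.

The compounds shown leave open whether any group at this aromatic carbon can move the number well beyond the span of these three. An amine or a carboxylic acid in this place, or a lone hydrogen, would test that.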